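The source may report more compounds than this note shows. Statements on the series, on what has been measured and on what is new or still open speak of the compounds shown alone.

Of the compounds shown here, two that share one core have been measured in an assay on HEK293 cells for displacement of a labelled ligand from metabotropic glutamate receptor 5 (Homo sapiens), with a stated time of 2 h; a lower number here means a stronger inhibitor, a higher number a weaker inhibitor. Compound 1, `Cc1ccccc1C#Cc1ccc2c(n1)CCN(C)C2=O`, is one of them. In this assay compound 1 gives only a limit, > 32000 nM, and not a number. Compound 2, `O=C1c2ccc(C#Cc3ccccc3)nc2CCN1C1CCCCC1`, is the other. In this assay compound 2 gives 12400 nM, the only full number shown, so compound 2 stands as the single measured point. The other value sits at the limit of > 32000 nM in this assay, at which 1 of the 2 values shown sits. Going by the values given here, compound 1 and compound 2 differ in more than one place, so no single step links them.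

Compound 3, `Cc1ccccc1C#Cc1ccc2c(n1)CCN(C1CCCCC1)C2=O`, differs from compound 2 by methyl in place of hydrogen on an aromatic carbon; read one bond further out, the change is phenyl to 2-methylphenyl. Among the compounds with values here, no measured pair shows this change on its own, and compound 1, which carries the same methyl, offers only a limit. The step from compound 2 to compound 3 is expected to be small, a 1.3-fold higher number from compound 2 to compound 3 (0.11 log units; within the scatter), not clearly beyond the scatter in either direction. Compound 3 is therefore estimated at 16000 nM, within 4000 nM to 60000 nM, with a real chance that this assay reports only a limit.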

Compound 3, inhibition constant: > 32000 nM
Compound 3: a limit, no number; the forecaster's own chance of this, stated with the estimate: 35%; middle value at least 2.0-fold (0.30 log units) from the limit.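

In this assay the change from phenyl to 2-methylphenyl can now be read on its own, and it gives an at least 2.5-fold higher number from compound 2 to compound 3 (0.41 log units; beyond the scatter), so a methyl on this aromatic carbon, ortho to a large group, goes with clearly weaker binding instead of leaving it unchanged. From the compounds shown here alone, compound 3 gives a limit and not a number, so this step is only a minimum and its full size stays unknown, while the step that swaps methyl for cyclohexyl on the ring nitrogen cannot be read. Compound 2 remains the only compound with a full number, so the series offers just one firm point of comparison: the limit of > 32000 nM in this assay, at which 2 of the 3 values shown sit.

The compounds shown cannot tell whether this loss belongs to methyl in particular or would also appear with a fluorine atom or a methoxy group at the same place, or with a methyl elsewhere on the phenyl ring. Going by these compounds, it also stays open whether the same change would cost as much with a group other than cyclohexyl on the ring nitrogen, such as a benzyl group or a chain ending in an amine.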